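A few compounds are considered here, and "the series" means these few. Any claim that something is new, unique, unknown or untested is made for them only; others in the source may bear on it.

Measured in a functional assay on L1210 (1565) cells (Mus musculus) for cytotoxicity; a higher number here means that more compound is needed for the effect, a lower number that less compound is needed:
- compound 1 `c1ccc(COc2cc(-c3ccccc3)nc3ccccc23)cc1` gives > 10 ug/mL as a limit
- compound 2 `CC(C)Oc1cc(-c2ccccc2)nc2ccccc12` gives > 10 ug/mL as a limit
- compound 3 `CCCCOc1cc(-c2ccccc2)nc2ccccc12` gives > 10 ug/mL as a limit

Compound 3 stands at > 10 ug/mL as a limit and not a number. The whole picture so far is the limit of > 10 ug/mL in this assay, at which 3 of the 3 values shown sit, and no actual number exists yet.

Next comes compound 4 `CS(=O)(=O)Oc1cc(-c2ccccc2)nc2ccccc12` in which methylsulfonyl stands in place of butyl on an oxygen on an aromatic ring (methylsulfonyl in place of butyl on an oxygen on an aromatic ring). Among the measured compounds shown here, three measured steps bear on this only loosely, each exchanging the group on that oxygen: a step that the two limits leave unreadable from compound 1 to compound 2 then a step that the two limits leave unreadable from compound 1 to compound 3 and a step that the two limits leave unreadable from compound 2 to compound 3 as well. For the measured compounds named here, none has a readable size, so they offer no measure for the new change, and no measured compound carries methylsulfonyl.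

The expectation therefore rests on compound 3 at > 10 ug/mL alone, with no step beyond the scatter expected in this assay and no direction favoured. The expected step is a number no higher from compound 3 to compound 4 (the limit leaves the size open) and it remains an estimate. For compound 4 the estimated value is 10 ug/mL with an expected range from 3 ug/mL to 30 ug/mL in this reading.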

Compound 4, half-maximal effective concentration: 6.04 ug/mL
Compound 4: the middle estimate sits 1.7-fold (0.22 log units) above what was measured; the measured number falls inside the stated range.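

Among the compounds shown here, with methylsulfonyl on the oxygen, compound 4 gives the first actual number in this assay, so this position can carry a group that yields a readable value, while benzyl, isopropyl and butyl leave only a limit: the limit of > 10 ug/mL in this assay, at which 3 of the 4 values shown sit. The exchange reads as an at least 1.6-fold lower number from compound 3 to compound 4 (0.21 log units; that floor lies within the scatter), as an at least 1.6-fold lower number from compound 2 to compound 4 (0.21 log units; that floor lies within the scatter) and as an at least 1.6-fold lower number from compound 1 to compound 4 (0.21 log units; that floor lies within the scatter). As far as these compounds go, each of these steps is only a floor, so its true size stays open, and what is secured so far does not go beyond the scatter.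

The compounds shown leave open whether a number also appears with another group on this oxygen, such as ethylsulfonyl or acetyl. They also leave open whether a butyl chain ending in an amine would give a readable value.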